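The source may hold more compounds than are shown below. What is called first, only, known or untested is meant among the compounds shown, and "the series" means these compounds.

Of the compounds shown here, three have so far been measured in a physicochemical assay for lipophilicity; a lower number here means a more polar compound, a higher number a more lipophilic compound. Compound 1 `COc1cccc(NC(=O)Nc2ccc3nc(Oc4ccc(F)cc4C(C)O)c(Cc4ccccc4)cc3c2)c1` gives 6.72. Compound 2 `CC(O)c1cc(F)ccc1Oc1nc2ccc(NS(=O)(=O)c3cccc(C(F)(F)F)c3)cc2cc1Cc1ccccc1` gives 7.69, and compound 3 `OC(c1ccccc1)c1c(C(F)(F)F)nc2ccc(Br)cc2c1Br` gives 6.26. Among these three numbers compound 1 stands second highest: compound 3 sits lower by a gap that is beyond the usual scatter, and compound 2 sits higher by a wider gap, also beyond the scatter.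

Compound 4 `COc1ccccc1NC(=S)Nc1ccc2nc(Oc3ccc(F)cc3C(C)O)c(Cc3ccccc3)cc2c1` has not yet been measured in this assay. It differs from compound 1 in one region, on a nitrogen on an aromatic ring: a group of 11 heavy atoms (8 carbon, 1 nitrogen, 1 oxygen, 1 sulfur; one six-membered aromatic ring of carbon only) in place of a group of 11 heavy atoms (8 carbon, 1 nitrogen, 2 oxygen; one six-membered aromatic ring of carbon only), on a nitrogen on an aromatic ring. The group that leaves carries a carbonyl; the group that enters keeps a methoxy-bearing aromatic ring of the same size but holds a sulfur where the second oxygen stood, so the counts of heavy atoms, hydrogen-bond donors and hydrogen-bond acceptors are unchanged.

For the measured compounds named here, none of the three measured compounds form a pair that shows this exchange, so no measured step can be leaned on. The step from compound 1 to compound 4 is expected to be a modest rise, a number 0.48 log units higher from compound 1 to compound 4 (beyond the scatter), only a little beyond the scatter. Compound 4 is therefore expected to give about 7.2 in this assay, within a range from 6.7 to 7.7.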

Compound 4, partition coefficient: 7.86
Beside the measured number, compound 4's estimate is 0.66 log units below it; the measured number lies above the stated range.
By their numbers in this assay, from the lowest: compound 3; then compound 1; then compounds 2 and 4 (each within the scatter of the next).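

For the compounds shown here, on a nitrogen on an aromatic ring, this exchange gives the first measured step in the set, and in this assay it is large: a number 1.14 log units higher from compound 1 to compound 4 (beyond the scatter). The two groups have the same counts of heavy atoms, hydrogen-bond donors and hydrogen-bond acceptors, so this number can move a long way even when those counts stay the same. No measurement at hand explains the rise.

The step also covers more than the sulfur standing where the carbonyl oxygen stood, since the methoxy does not occupy the same place on the ring in the two groups, and the compounds shown cannot separate these two differences. A single pair also leaves open whether a step of this size would recur on another compound, or what would happen with an amine or a carboxylic acid in place of the methoxy.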